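A few compounds are considered here, and "the series" means these few. Any claim that something is new, unique, unknown or untested is made for them only; others in the source may bear on it.

Measured so far:
compound 1, `C=CCNc1[nH]nc(N)c1C(=O)Nc1ccc(OCC)cc1`, 30800 nM
compound 2, `CCNc1[nH]nc(N)c1C(=O)Nc1ccc(OCC)cc1`, 14800 nM
compound 3, `CCNc1[nH]nc2nnn(-c3ccc(OCC)cc3)c(=O)c12`, 16100 nM

All three were tested in a functional assay on PANC-1 cells (Homo sapiens) for cytotoxicity, read by resazurin assay, with a stated time of 48 h; a lower number here means a stronger inhibitor, a higher number a weaker inhibitor. Compound 2 and compound 1 share one core and differ by vinyl in place of methyl on a saturated chain carbon bound to a nitrogen on an aromatic ring; that step reads a 2.1-fold higher number from compound 2 to compound 1 (0.32 log units; beyond the scatter). Compound 3 carries a different core; the difference between the two cores is not broken down here. Compound 4, `C=CCNc1[nH]nc2nnn(-c3ccc(OCC)cc3)c(=O)c12`, has not yet been measured in this assay. It differs from compound 3 by vinyl in place of methyl on a saturated chain carbon bound to a nitrogen on an aromatic ring, the same change at the same place as the step from compound 2 to compound 1. The change occurs only once among the measured compounds. Because that one occurrence read a 2.1-fold higher number from compound 2 to compound 1 (0.32 log units; beyond the scatter), a step of similar size is expected here: a 2.1-fold higher number from compound 3 to compound 4 (0.32 log units; beyond the scatter). Compound 4 is therefore estimated at 34000 nM, with a likely range from 17000 nM to 70000 nM.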

Compound 4, half-maximal inhibitory concentration: 13300 nM
Compound 4: middle estimate off by 2.6-fold (0.41 log units), on the high side; the measured number lies below the stated range.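

In this assay, going from ethylamino to allylamino gives a 1.2-fold lower number from compound 3 to compound 4 (0.08 log units; within the scatter), so on this core the change makes no clear difference. Set beside the earlier step, this result does not separate from it: the same change on two cores in this assay, a 2.1-fold higher number (0.32 log units; beyond the scatter) from compound 2 to compound 1 and a 1.2-fold lower number (0.08 log units; within the scatter) from compound 3 to compound 4, 2.5-fold (0.40 log units) apart, within the scatter of two such steps. Within the data shown here, the two cores therefore cannot be told apart in their response to this change, but with only one pair on each core, this shows neither that the step carries over reliably nor that it depends on the core.

The compounds shown leave open how a longer chain such as butyl, an amine or a carboxylic acid in place of the allyl group would read on either core. They also leave open how the same change would read on a third core.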